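Replacing 2,4-dichlorophenyl with 4-isopropylphenyl in compound 3

The source may hold more compounds than are shown below. What is called first, only, known or untested is meant among the compounds shown, and "the series" means these compounds.

Measured so far in a functional assay, read by spectrophotometry, tested at 100 uM; a lower number here means a stronger inhibitor, a higher number a weaker inhibitor:
- compound 1 `CN(C)c1ccc(/C=C/C(=O)c2cccc(NC(=O)c3cc(-c4ccncc4)n[nH]3)c2)cc1`: 41900 nM
- compound 2 `O=C(/C=C/c1ccc([N+](=O)[O-])cc1)c1cccc(NC(=O)c2cc(-c3ccncc3)n[nH]2)c1`: 52800 nM
- compound 3 `O=C(/C=C/c1ccc(Cl)cc1Cl)c1cccc(NC(=O)c2cc(-c3ccncc3)n[nH]2)c1`: 35000 nM

In this assay compound 3 stands at 35000 nM, within the scatter of both other compounds, so it cannot be separated from them. The next compound to be read is compound 4 `CC(C)c1ccc(/C=C/C(=O)c2cccc(NC(=O)c3cc(-c4ccncc4)n[nH]3)c2)cc1`. The change is 4-isopropylphenyl in place of 2,4-dichlorophenyl on a double-bonded chain carbon bound to a double-bonded chain carbon.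

Among the compounds with values here, three measured steps bear on this, all exchanges at the same aromatic group: a 1.2-fold lower number from compound 1 to compound 3 (0.08 log units; within the scatter), a 1.5-fold lower number from compound 2 to compound 3 (0.18 log units; within the scatter) and a 1.3-fold higher number from compound 1 to compound 2 (0.10 log units; within the scatter). Within the data shown here, none goes beyond the scatter, although only three compounds support this flat picture, none of which carries 4-isopropylphenyl. No step beyond the scatter is therefore expected in this assay, and no direction can be favoured. The expected step is a 1.1-fold higher number from compound 3 to compound 4 (0.06 log units; within the scatter). The estimate for compound 4 is 40000 nM, with an expected range from 22000 nM to 72000 nM.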

Compound 4, half-maximal inhibitory concentration: 52300 nM
Beside the measured number, compound 4's estimate is 1.3-fold (0.12 log units) below it; low and high end bracket the measured number.
By their numbers in this assay, from the lowest: compounds 3, 1, 4 and 2 (each within the scatter of the next).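

Compound 4 adds three readings at this position in this assay and all stay within the scatter: a 1.5-fold higher number from compound 3 to compound 4 (0.17 log units; within the scatter) and a 1.0-fold lower number from compound 2 to compound 4 (0.00 log units; within the scatter) and also a 1.2-fold higher number from compound 1 to compound 4 (0.10 log units; within the scatter). The flat picture therefore now extends to 4-isopropylphenyl, whose substituent is carbon only, so compound 1, compound 2, compound 3 and compound 4 cannot be separated in this assay despite their different substituents on the phenyl group. Nothing in the available data offers an explanation for this flatness.

Going by these compounds, it remains open whether any group at this place can move the number beyond the scatter, for example a phenyl group carrying a carboxylic acid, a primary amine or a longer alkyl chain. Also open, on these data alone, is whether replacing the phenyl group with a saturated ring would do so.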